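Sulfamoyl in Place of Methoxy on an Aryl Oxazole Ketone

The source may report more compounds than this note shows. Statements on the series, on what has been measured and on what is new or still open speak of the compounds shown alone.

Compound 1, `O=C(CCCCCCc1ccccc1)c1ncc(-c2ccc(F)cc2)o1`, gives 62 nM in an assay (Rattus norvegicus) for inhibition of Fatty-acid amide hydrolase 1 (Homo sapiens); a higher number here means a weaker inhibitor, a lower number a stronger inhibitor.
Compound 2, `COc1ccc(-c2cnc(C(=O)CCCCCCc3ccccc3)o2)cc1`, gives 100 nM in this assay.

Going by the values given here, compound 2 holds the higher of the two numbers so far, yet its only neighbour, compound 1, sits within the scatter of it: a 1.6-fold higher number from compound 1 to compound 2 (0.21 log units; within the scatter). Compound 3, `NS(=O)(=O)c1ccc(-c2cnc(C(=O)CCCCCCc3ccccc3)o2)cc1`, has not yet been measured. It differs from compound 2 by sulfamoyl in place of methoxy on an aromatic carbon. Among the compounds with values here, the one measured step that bears on this position, the exchange of fluoro for methoxy, was small, a 1.6-fold higher number from compound 1 to compound 2 (0.21 log units; within the scatter), and no step with a sulfamoyl group has been measured at all. A change of modest size in either direction is therefore expected, no change at the digits printed from compound 2 to compound 3 (within the scatter), with a wide range. Compound 3 is estimated at 100 nM in this assay, between 25 nM and 400 nM.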

Compound 3, inhibition constant: 10 nM
Compound 3: middle estimate off by 10-fold (1.00 log units), on the high side; the measured number lies below the stated range.
By their numbers in this assay, from the lowest: compound 3; then compounds 1 and 2 (each within the scatter of the next).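

In this assay, putting sulfamoyl in place of methoxy gives a 10-fold lower number from compound 2 to compound 3 (1.00 log units; beyond the scatter) and putting it in place of fluoro gives a 6.2-fold lower number from compound 1 to compound 3 (0.79 log units; beyond the scatter), so this position responds clearly to the group it carries, although the exchange between fluoro and methoxy had stayed within the scatter. Compound 3 holds the lowest number of the three, and its steps to both other compounds are beyond the scatter. Nothing measured here explains the gain or ties it to any feature of the sulfamoyl group.

On these data alone, it remains open whether the gain needs the whole sulfamoyl group, which a methylsulfonyl group, a primary carboxamide or a carboxylic acid on the same aromatic carbon could test. As far as these compounds go, it also remains open whether the gain would persist with a shorter chain in place of the one in the shared core.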